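The compounds below may be only part of what the source reports. "The series", "measured", "known", "first", "only" and "open" are said of these compounds alone.

Measured so far in a functional assay on HepG2 cells (Homo sapiens) for antiproliferative activity, read by CCK-8 assay, with a stated time of 48 h; a higher number here means a weaker inhibitor, a lower number a stronger inhibitor:

- compound 1 `COc1ccc(/C=C\c2cc(OC)c(OC)c(OC)c2)cc1OCc1ccc(C=O)cc1`: 800 nM
- compound 2 `COc1ccc(/C=C\c2cc(OC)c(OC)c(OC)c2)cc1OCc1ccc(CN2CC[C@H](O)C2)cc1`: 6600 nM
- compound 3 `COc1ccc(/C=C\c2cc(OC)c(OC)c(OC)c2)cc1OCc1ccc(CN2CC[C@@H](O)C2)cc1`: 6200 nM

Among these three, compound 1 has the lowest number, so it is the strongest inhibitor of the set. Both other compounds carry a (3-hydroxypyrrolidin-1-yl)methyl group in place of its formyl group, and each of them gives a markedly higher number: an 8.3-fold higher number from compound 1 to compound 2 (0.92 log units; beyond the scatter) and a 7.8-fold higher number from compound 1 to compound 3 (0.89 log units; beyond the scatter). The two of them differ from one another only in how one stereocentre is drawn, and their numbers sit within the scatter of each other (a 1.1-fold lower number from compound 2 to compound 3 (0.03 log units; within the scatter)), which fits (the fact that compounds 2 and 3 differ only in the configuration as drawn).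

Compound 4 `COc1ccc(/C=C\c2cc(OC)c(OC)c(OC)c2)cc1OCc1ccc(CN[C@H](C(=O)O)[C@@H](C)O)cc1` is the next step from compound 1. Its change is ((1-carboxy-2-hydroxypropyl)amino)methyl in place of formyl on an aromatic carbon. As in the two measured steps, a formyl group gives way to a group joined through a methylene to a nitrogen that also carries a hydroxyl-bearing chain; here the chain additionally holds a carboxylic acid. Since both measured replacements of the formyl group raised the number by a modest but clear amount, a rise of similar size is expected here, in this assay, rather than a change within the scatter. The expected step is a 10-fold higher number from compound 1 to compound 4 (1.00 log units; beyond the scatter). For compound 4 the estimate in this assay is therefore 8000 nM, with a range from 2500 nM to 25000 nM.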

Compound 4, half-maximal inhibitory concentration: > 10000 nM
Compound 4 was reported as a limit (the forecaster's own chance of this, stated with the estimate: 10%); at least 1.2-fold (0.09 log units) between middle value and limit.
By their numbers in this assay, from the lowest: compound 1; then compounds 3 and 2 (each within the scatter of the next). At a limit, above all of these: compound 4.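

In this assay compound 4 gives > 10000 nM and this is a limit, not a number. Even so, the step at this position, on an aromatic carbon para to a large group, can be read as a clear loss (an at least 12-fold higher number from compound 1 to compound 4 (1.09 log units; beyond the scatter)), so an open-chain amine holding a carboxylic acid joins the two 3-hydroxypyrrolidin-1-yl compounds in giving a higher number than the formyl group of compound 1. Against those two compounds the limit settles little, since both steps only give floors within the scatter (an at least 1.6-fold higher number from compound 3 to compound 4 (0.20 log units; that floor lies within the scatter); an at least 1.5-fold higher number from compound 2 to compound 4 (0.18 log units; that floor lies within the scatter)), and compound 4 may sit close to them or well beyond them.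

The compounds shown leave open which part of the new group goes with the higher number: the carboxylic acid, the hydroxyl or the open chain. A methyl ester in place of the carboxylic acid, or a plain dimethylamino group in place of the whole hydroxyl-bearing amine, would help separate these parts and show whether any amine at this position can come close to the formyl group.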